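This account rests on a few compounds, and the source may have more. Where it says the series, first, only, none or still open, it means among the compounds named here.

Measured in a functional assay on NIH3T3 cells (Mus musculus); a lower number here means that less compound is needed, a higher number that more compound is needed for the effect:
- compound 1 `Cn1cncc1C(OCc1ccc(C#N)cc1C#Cc1ccccn1)c1ccc(C#N)cc1`: > 0.1 nM
- compound 2 `CCC/C=C/C=C/c1cc(C#N)ccc1COC(c1ccc(C#N)cc1)c1cncn1C`: 16.7 nM
- compound 3 `Cn1cncc1C(OCc1ccc(C#N)cc1/C=C/c1ccccn1)c1ccc(C#N)cc1`: 23.1 nM

Compound 1 is known only through a limit, > 0.1 nM. Compound 4 `Cn1cncc1C(OCc1ccc(C#N)cc1C#Cc1ccc(-c2ccccc2)cc1)c1ccc(C#N)cc1` differs from it as follows: 4-phenylphenyl in place of pyridin-2-yl on a triple-bonded carbon. The exchange places 4-phenylphenyl in place of pyridin-2-yl on a triple-bonded carbon. Neither a step that the limit leaves unreadable from compound 1 to compound 2 nor a step that the limit leaves unreadable from compound 1 to compound 3 gives a usable size. Going by the values given here, the only readable step, a 1.4-fold higher number from compound 2 to compound 3 (0.14 log units; within the scatter), exchanges pyridin-2-yl for pent-1-en-1-yl on a double-bonded chain carbon and stays within the scatter. No step beyond the scatter is therefore expected from that evidence, and compound 4 is expected to lie near compound 2 and compound 3. The expected step is a step that the limit leaves unreadable from compound 1 to compound 4, though it is read against a limit. In this assay, compound 4 is estimated at 20 nM, with an expected range of 4 nM to 100 nM.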

Compound 4, half-maximal effective concentration: > 0.1 nM
Compound 4: only a limit was reported (the forecaster's own chance of this, stated with the estimate: 15%); the middle value lies beyond the limit too.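

No step can be read from compound 1 to compound 4, as each is known only through a limit: the limit of > 0.1 nM in this assay, at which 2 of the 4 values shown sit.

The compounds shown leave open how 4-phenylphenyl compares with pyridin-2-yl on the triple-bonded carbon in this assay.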